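From Bromo to Methyl on the Shared Core

The source may hold more compounds than are shown below. What is called first, only, known or untested is meant among the compounds shown, and "the series" means these compounds.

For the measured compounds named here, in a functional assay on HeLa cells (Homo sapiens) for antiproliferative activity, read by MTT assay (a lower number here means a stronger inhibitor, a higher number a weaker inhibitor), compound 2 `Clc1ccc(Nc2nccc(-c3ccc(Br)cc3)n2)c(Cl)c1` gives 1080 nM, the lower of the two numbers measured so far. Going by the values given here, its only measured neighbour, compound 1 `COc1ccc(-c2ccnc(Nc3ccc(Cl)cc3Cl)n2)cc1`, gives 23000 nM. The next structure, compound 3 `Cc1ccc(-c2ccnc(Nc3ccc(Cl)cc3Cl)n2)cc1`, carries methyl in place of bromo on an aromatic carbon, para to a large group: methyl in place of bromo on an aromatic carbon. Among the compounds with values here, one measured step bears on this change: a 21-fold lower number from compound 1 to compound 2 (1.33 log units; beyond the scatter), a large step beyond the scatter, with bromo in place of methoxy on the same aromatic carbon. Within the data shown here, it shows that the number can move strongly with this group, but no measured compound carries methyl. A moderate rise in this assay is therefore expected on losing the bromo. The estimated step is a 4.6-fold higher number from compound 2 to compound 3 (0.67 log units; beyond the scatter). Compound 3 is expected at 5000 nM, within an estimated range from 1500 nM to 20000 nM.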

Compound 3, half-maximal inhibitory concentration: 91500 nM
Beside the measured number, compound 3's estimate is 18-fold (1.26 log units) below it; the measured number lies above the stated range.
By their numbers in this assay, from the lowest: compound 2; then compound 1; then compound 3.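

In this assay, replacing bromo with methyl on this aromatic carbon, para to a large group, raises the number sharply, with an 85-fold higher number from compound 2 to compound 3 (1.93 log units; beyond the scatter) as the large step at this position. Methyl also stands above methoxy, with a 4.0-fold higher number from compound 1 to compound 3 (0.60 log units; beyond the scatter) as a modest step, so methoxy, the weaker of the two groups compared earlier, now falls in the middle of the three, and bromo is the only one of them that gives a low number. No measurement among the data shown accounts for this order.

The compounds shown leave open whether an amine, a carboxylic acid or a longer chain such as propyl on this carbon would fall within the same span. They also leave open whether chloro or iodo would come closer to bromo than methyl does.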